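Adding a nitro group to the benzyl of compound 3

The source may report more compounds than this note shows. Statements on the series, on what has been measured and on what is new or still open speak of the compounds shown alone.

Of the compounds shown here, three on the shared core have been measured: compound 1 `C=C1C(=O)O[C@H]2[C@H]1CC/C(COC(=O)CCC(=O)OCn1cc(F)c(=O)[nH]c1=O)=C\CC[C@@]1(C)O[C@@H]21`, compound 2 `C=C1C(=O)O[C@H]2[C@H]1CC/C(COC(=O)CCC(=O)NCCCCCCNC(=O)Cn1cc(F)c(=O)[nH]c1=O)=C\CC[C@@]1(C)O[C@@H]21` and compound 3 `C=C1C(=O)O[C@H]2[C@H]1CC/C(COC(=O)Cn1cc(F)c(=O)n(Cc3ccccc3)c1=O)=C\CC[C@@]1(C)O[C@@H]21`. In a functional assay on Bel-7402 cells (Homo sapiens) for antiproliferative activity, read by MTT assay, with a stated time of 72 h (a higher number here means a weaker inhibitor, a lower number a stronger inhibitor), compound 1 gives > 20000 nM, which is a limit of the assay and not a number. Compound 2 gives > 20000 nM, likewise a limit. Among the measured compounds shown here, compound 3 gives 3980 nM, the only true number so far. The remaining values are summarised by the limit of > 20000 nM in this assay, at which 2 of the 3 values shown sit.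

The next entry is compound 4 `C=C1C(=O)O[C@H]2[C@H]1CC/C(COC(=O)Cn1cc(F)c(=O)n(Cc3ccc([N+](=O)[O-])cc3)c1=O)=C\CC[C@@]1(C)O[C@@H]21`. It differs from compound 3 by nitro in place of hydrogen on an aromatic carbon, which turns benzyl into 4-nitrobenzyl. For the measured compounds named here, no measured pair shows the size of such a change, so the expectation rests only on compound 3 at 3980 nM. In this assay the expected change is a 1.3-fold lower number from compound 3 to compound 4 (0.12 log units; within the scatter), with no shift expected beyond the scatter. For compound 4 the estimated value is 3000 nM, with an expected range of 1000 nM to 10000 nM.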

Compound 4, half-maximal inhibitory concentration: 4070 nM
Estimate against measurement, compound 4: 1.4-fold (0.13 log units) below; measured number inside the range.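

Among the compounds shown here, the step from benzyl to 4-nitrobenzyl is the first comparison that differs in one place, and in this assay it reads a 1.0-fold higher number from compound 3 to compound 4 (0.01 log units; within the scatter). This aromatic carbon, para to a large group, therefore accepts a nitro group with its 3 heavy atoms, and the read-out stays within the scatter of the unsubstituted benzyl. Nothing measured in the series gives a cause for this result.

As far as these compounds go, whether the same holds for an amine, a carboxylic acid or a methoxy group on this carbon remains open, as does the effect of any group on the other aromatic carbons of the benzyl. Compound 1 and compound 2 differ from compound 3 in more than one place, so the role of the benzyl itself cannot be read from the compounds shown.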